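Aminoalkyl amide variation at the carbonyl carbon

The source may hold more compounds than are shown below. What is called first, only, known or untested is meant among the compounds shown, and "the series" means these compounds.

Compound 1 `COc1ncc(-c2ccc3ncnc(N[C@H]4CCCN(C(=O)c5cccnc5)C4)c3c2)cc1C#N` carries pyridin-3-yl on the carbonyl carbon of the ring amide; in an assay on isolated protein for inhibition of phosphatidylinositol 4,5-bisphosphate 3-kinase catalytic subunit beta isoform (Homo sapiens), read by luminescence and Kinase-Glo, with a stated time of 60 min, in the presence of a further agent that is not named here (a higher number here means a weaker inhibitor, a lower number a stronger inhibitor), compound 1 gives 9.1 nM. Compound 2 `COc1ncc(-c2ccc3ncnc(N[C@H]4CCCN(C(=O)CN(C)C)C4)c3c2)cc1C#N` carries (dimethylamino)methyl in that position instead, and in this assay compound 2 gives 150 nM. For the measured compounds named here, the step of a 16-fold higher number from compound 1 to compound 2 (1.22 log units; beyond the scatter) is the only measured step so far. Compound 2 therefore stands at the highest of the two numbers measured, with compound 1 as its nearest neighbour.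

Compound 3 `COc1ncc(-c2ccc3ncnc(N[C@H]4CCCN(C(=O)C(C)N)C4)c3c2)cc1C#N` differs from compound 2 by 1-aminoethyl in place of (dimethylamino)methyl on a carbonyl carbon. Going by the values given here, the single measured step, a 16-fold higher number from compound 1 to compound 2 (1.22 log units; beyond the scatter), concerns the exchange of an aromatic ring for an aminoalkyl chain on the same carbonyl carbon and is large; the change from compound 2 to compound 3 stays within aminoalkyl chains, so no measured step bears directly on it. In this assay the expected step for compound 3 is a 1.3-fold lower number from compound 2 to compound 3 (0.10 log units; within the scatter), that is, a number expected close to that of compound 2 and not beyond the scatter. Compound 3 is thus estimated at 120 nM, with a range from 40 nM to 400 nM.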

Compound 3, half-maximal inhibitory concentration: 147 nM
Beside the measured number, compound 3's estimate is 1.2-fold (0.09 log units) below it, within the range that was stated.
By their numbers in this assay, from the lowest: compound 1; then compounds 3 and 2 (each within the scatter of the next).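

In this assay, 1-aminoethyl in place of (dimethylamino)methyl on the carbonyl carbon gives a 1.0-fold lower number from compound 2 to compound 3 (0.01 log units; within the scatter), so these two aminoalkyl chains are not separated here, even though the entering group carries a hydrogen-bond donor that the leaving group lacks. The gap to pyridin-3-yl now rests on two chains rather than one: alongside a 16-fold higher number from compound 1 to compound 2 (1.22 log units; beyond the scatter) there is a 16-fold higher number from compound 1 to compound 3 (1.21 log units; beyond the scatter), and neither aminoalkyl compound goes against this among the three compounds shown. Nothing available explains either the gap to pyridin-3-yl or the absence of a separation between the two chains.

Open, going by these compounds, is whether the lower number of compound 1 belongs to pyridin-3-yl in particular or to aromatic rings on this carbonyl carbon more generally, a question that phenyl or pyridin-4-yl would address. Also open, on these data alone, is whether the nitrogen of the chain matters at all, which a plain alkyl group such as ethyl would test, and whether a longer chain ending in an amine or a ring amine such as pyrrolidin-2-yl would stay with compounds 2 and 3 or move towards compound 1.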